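The source may hold more compounds than are shown below. What is called first, only, known or untested is meant among the compounds shown, and "the series" means these compounds.

Measured so far:
compound 1 `CC(O)(CSc1ccc(S(F)(F)(F)(F)F)cc1)C(=O)Nc1ccc(S(F)(F)(F)(F)F)cc1` gives 28000 nM
compound 2 `CC(O)(CSc1ccc(C(F)(F)F)cc1)C(=O)Nc1ccc(S(F)(F)(F)(F)F)cc1` gives 24800 nM
compound 3 `CC(O)(COc1ccc(S(F)(F)(F)(F)F)cc1)C(=O)Nc1ccc(S(F)(F)(F)(F)F)cc1` gives 9300 nM

All three were run in a functional assay on VCaP cells (Homo sapiens) for antiproliferative activity, read by propidium iodide staining, with a stated time of 96 h; on this read-out lower numbers stand for stronger inhibition and higher numbers for weaker inhibition. Compound 2 differs from compound 1 by a group of 4 heavy atoms (1 carbon, 3 fluorine; no ring) in place of a group of 6 heavy atoms (5 fluorine, 1 sulfur; no ring), on an aromatic carbon; that step made a 1.1-fold lower number from compound 1 to compound 2 (0.05 log units; within the scatter). Compound 3 has a different core from compound 1, and the difference between the two cores is not broken down here. In this assay compound 3 gives the lowest number of the three, with compound 2 the nearest.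

Compound 4 `CC(O)(COc1ccc(S(F)(F)(F)(F)F)cc1)C(=O)Nc1ccc(C(F)(F)F)cc1` is not yet measured. It differs from compound 3 by a group of 4 heavy atoms (1 carbon, 3 fluorine; no ring) in place of a group of 6 heavy atoms (5 fluorine, 1 sulfur; no ring), on an aromatic carbon, which is the same change as from compound 1 to compound 2, at a place described in the same words. A step of similar size is expected, a 1.1-fold lower number from compound 3 to compound 4 (0.04 log units; within the scatter), because the earlier instance made a 1.1-fold lower number from compound 1 to compound 2 (0.05 log units; within the scatter). Compound 4 is therefore expected to give about 8500 nM, with a range from 4000 nM to 18000 nM.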

Compound 4, half-maximal inhibitory concentration: 14700 nM
Compound 4: middle estimate off by 1.7-fold (0.24 log units), on the low side; the range from low to high includes it.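

In this assay, trifluoromethyl in place of the group of 6 heavy atoms gives a 1.6-fold higher number from compound 3 to compound 4 (0.20 log units; within the scatter), and this step agrees with the earlier instance of the change: the same change on two cores in this assay, a 1.1-fold lower number (0.05 log units; within the scatter) from compound 1 to compound 2 and a 1.6-fold higher number (0.20 log units; within the scatter) from compound 3 to compound 4, 1.8-fold (0.25 log units) apart, within the scatter of two such steps

Across these two cores, the exchange therefore shows no step beyond the scatter, and the two groups cannot be told apart in this read-out. Among these compounds, this rests on only two pairs, with the change on a different aromatic ring in each, so it does not show that the exchange would stay this small on other cores.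

The compounds shown leave open how a nitrile, a chlorine or an amine would behave in the same place. They also leave open whether the exchange behaves alike on a core with a carbon chain in place of the oxygen or sulfur link.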